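The source may hold more compounds than are shown below. What is called first, only, known or untested is meant among the compounds shown, and "the series" means these compounds.

The measured compounds:
compound 1, `CC1(C)CCN(S(=O)(=O)CCCN2CCC(CNC(=O)c3cccc4c3OCCO4)CC2)CC1`, gives 0.126 nM in an assay on isolated protein for inhibition of 5-hydroxytryptamine receptor 4 (Homo sapiens); on this read-out lower numbers stand for stronger inhibition and higher numbers for weaker inhibition
compound 2, `CCCS(=O)(=O)N1CCN(S(=O)(=O)CCCN2CCC(CNC(=O)c3cccc4c3OCCO4)CC2)CC1`, gives 0.1 nM in this assay

Among the compounds with values here, compound 2 sits at one of only two numbers in this assay, and its nearest neighbour, compound 1, is within the scatter of it, so the two cannot be told apart on this read-out. Within the data shown here, the one measured step, a 1.3-fold lower number from compound 1 to compound 2 (0.10 log units; within the scatter), is the only step that bears on the change to compound 3, `CCCC1CCN(S(=O)(=O)CCCN2CCC(CNC(=O)c3cccc4c3OCCO4)CC2)CC1`, and it shows that swapping the group on the sulfonyl sulfur did not move the number beyond the scatter.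

The change now is 4-propylpiperidin-1-yl in place of 4-(propylsulfonyl)piperazin-1-yl on a sulfonyl sulfur. Among the measured compounds shown here, the entering group is of the same kind as the one in compound 1, a piperidine with alkyl substitution, and compound 1 and compound 2 gave numbers within the scatter of each other in this assay. Compound 3 is therefore expected to show no step beyond the scatter, a 1.2-fold higher number from compound 2 to compound 3 (0.08 log units; within the scatter), in this assay. The estimate for compound 3 in this assay is 0.12 nM, with a range from 0.04 nM to 0.35 nM.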

Compound 3, inhibition constant: 0.0631 nM
Compound 3: middle estimate off by 1.9-fold (0.28 log units), on the high side, and the stated range covers the measured number.
By their numbers in this assay, from the lowest: compounds 3, 2 and 1 (each within the scatter of the next).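

In this assay the place on the sulfonyl sulfur now carries three different groups that the read-out does not separate: a 1.6-fold lower number from compound 2 to compound 3 (0.20 log units; within the scatter), and a 2.0-fold lower number from compound 1 to compound 3 (0.30 log units; within the scatter). The step from compound 2 replaces a group with 2 hydrogen-bond acceptors and a second ring nitrogen by a group with 0 hydrogen-bond acceptors and a single ring nitrogen, and even this larger difference in make-up stays within the scatter, as does the change of 4,4-dimethylpiperidin-1-yl to 4-propylpiperidin-1-yl. No measurement at hand offers an explanation for these numbers.

As far as these compounds go, all three groups are six-membered non-aromatic rings attached through a ring nitrogen, so it remains open whether an open-chain amine such as diethylamino, or a ring bearing a carboxylic acid, would move the number beyond the scatter. From the compounds shown here alone, it is equally open whether a hexyl chain in place of the propyl on the piperidine would stay within the scatter of these three compounds.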